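Swapping the acyl chain on a sulfonate ester series

The source may hold more compounds than are shown below. What is called first, only, known or untested is meant among the compounds shown, and "the series" means these compounds.

Three compounds have numbers so far:
compound 1 `CCCC(=O)Nc1ccc(S(=O)(=O)Oc2ccccc2C(C)C)cc1` with 6100 nM
compound 2 `CCCC(=O)Nc1ccc(S(=O)(=O)Oc2ccccc2I)cc1` with 9000 nM
compound 3 `CC(C)C(=O)Nc1ccc(S(=O)(=O)Oc2ccccc2C(C)C)cc1` with 11000 nM

All three were tested in a functional assay on M21 cells (Homo sapiens) for antiproliferative activity, read by sulforhodamine B assay, with a stated time of 48 h; on this read-out lower numbers stand for stronger inhibition and higher numbers for weaker inhibition. Compound 2 stands second highest of the three numbers, with compound 3 nearest and compound 1 furthest, though both gaps are within the scatter, so the three cannot be ranked against each other. The step of a 1.8-fold higher number from compound 1 to compound 3 (0.26 log units; within the scatter) shows that changing the acyl chain from propyl to isopropyl left the number essentially where it was.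

Compound 4 `O=C(CCl)Nc1ccc(S(=O)(=O)Oc2ccccc2I)cc1` is the untested compound. It differs from compound 2 by chloro in place of ethyl on a saturated chain carbon bound to a carbonyl carbon. Within the data shown here, the only measured step that touches the acyl chain is a 1.8-fold higher number from compound 1 to compound 3 (0.26 log units; within the scatter), and it was within the scatter. Among the measured compounds shown here, no measured step replaces a carbon chain with a chloro on this position, so the evidence is thin. On that basis a step of a 1.3-fold lower number from compound 2 to compound 4 (0.11 log units; within the scatter) is expected, which is not beyond the scatter in either direction. Compound 4 is therefore estimated at 7000 nM, within a range from 2000 nM to 25000 nM in this assay.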

Compound 4, half-maximal inhibitory concentration: 3900 nM
For compound 4 the middle estimate is 1.8-fold (0.25 log units) above the measured one, and the stated range covers the measured number.
By their numbers in this assay, from the lowest: compounds 4, 1, 2 and 3 (each within the scatter of the next, the first and the last beyond it).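

Among these compounds, the acyl end is the first place in this set where a single change moves the number beyond the scatter: in this assay there is a 2.3-fold lower number from compound 2 to compound 4 (0.36 log units; beyond the scatter), a modest shift. The earlier change at this end, a 1.8-fold higher number from compound 1 to compound 3 (0.26 log units; within the scatter), stayed within the scatter, but it only swapped one carbon chain for another, whereas here chloromethyl replaces propyl and the number does respond. No measurement shown gives a reason for this shift.

The compounds shown cannot separate the effect of the chloro from that of the shorter chain, and a methyl or a bromo in place of the chloro would help to tell these apart. On these data alone, it also stays open whether the change would give a similar step on the core of compound 1, which carries isopropyl where compound 2 carries iodo.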